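The source may report more compounds than this note shows. Statements on the series, on what has been measured and on what is new or still open speak of the compounds shown alone.

Working notes on the series, read in a functional assay on SW480 cells (Homo sapiens) for antiproliferative activity, read by MTT assay, with a stated time of 72 h; a higher number here means a weaker inhibitor, a lower number a stronger inhibitor. Compound 1 `Cc1nnc(Sc2coc3ccccc3c2=O)o1` gives > 50000 nM, which is a limit of the assay. Compound 2 `Cc1nnc(Sc2coc3ccccc3c2=O)s1` gives > 50000 nM, also a limit, so it has no number to start from. Going by the values given here, the only measured step is a step that the two limits leave unreadable from compound 1 to compound 2, with 5-methyl-1,3,4-thiadiazol-2-yl in place of 5-methyl-1,3,4-oxadiazol-2-yl on a sulfur. The evidence on it is the limit of > 50000 nM in this assay, at which 2 of the 2 values shown sit. Compound 3 `Nc1nnc(Sc2coc3ccccc3c2=O)s1` differs from compound 2 by amino in place of methyl on an aromatic carbon. The measured step therefore gives no size to carry over, and a limit may well recur. In this assay, only a modest move towards a lower number is expected, estimated as an at least 1.2-fold lower number from compound 2 to compound 3 (0.09 log units; that floor lies within the scatter). For compound 3 the estimate is 40000 nM, with an expected range of 12000 nM to 50000 nM.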

Compound 3, half-maximal inhibitory concentration: > 50000 nM
Compound 3 ended at the assay's limit; the forecaster's own chance of this, stated with the estimate: 60%; at least 1.2-fold (0.09 log units) between middle value and limit.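

No new step can be read among compound 1, compound 2 and compound 3 in this assay, since all three values are limits of the assay: the limit of > 50000 nM in this assay, at which 3 of the 3 values shown sit.

The compounds shown leave open how methyl and amino rank, and whether any change to the shared core gives a readable number.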